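This account rests on a few compounds, and the source may have more. Where it says the series, first, only, none or still open, it means among the compounds named here.

Series notes. For the measured compounds named here, compound 1 `Cn1ncc(Cl)c1-c1cc(C(=O)N[C@@H]2CN[C@H](CC(O)CO)C[C@H]2c2ccc(F)c(F)c2)oc1Cl` gives 3.31 nM in an assay for inhibition of RAC-alpha serine/threonine-protein kinase (Homo sapiens), read by HTRF, with a stated time of 1 h (on this read-out lower numbers stand for stronger inhibition and higher numbers for weaker inhibition), the second highest of the three numbers so far. Compound 2 `Cn1ncc(Cl)c1-c1cc(C(=O)N[C@@H]2CN[C@H](CC(O)CO)C[C@H]2c2ccc(Cl)c(Cl)c2)oc1Cl` gives 3.79 nM, and compound 3 `Cn1ncc(Cl)c1-c1cc(C(=O)N[C@@H]2CN[C@H](CC(=O)O)C[C@H]2c2ccc(Cl)c(Cl)c2)oc1Cl` gives 1.94 nM; all three sit within the scatter of one another, so no order among them can be read. The steps recorded are a 1.1-fold higher number from compound 1 to compound 2 (0.06 log units; within the scatter) and a 2.0-fold lower number from compound 2 to compound 3 (0.29 log units; within the scatter), both within the scatter.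

Compound 4 `CC(=O)OCC[C@@H]1C[C@@H](c2ccc(F)c(F)c2)[C@H](NC(=O)c2cc(-c3c(Cl)cnn3C)c(Cl)o2)CN1` differs from compound 1 by acetoxymethyl in place of 1,2-dihydroxyethyl on a saturated chain carbon bound to a saturated ring carbon. The step that bears on this position is a 2.0-fold lower number from compound 2 to compound 3 (0.29 log units; within the scatter), where a change at the same saturated chain carbon left the number within the scatter; the aryl change a 1.1-fold higher number from compound 1 to compound 2 (0.06 log units; within the scatter) is not at this position but likewise moved nothing beyond the scatter. Data on a chain that carries no hydrogen-bond donor at this position are absent. The expectation for this assay is therefore a step from compound 1 to compound 4 of a 1.4-fold higher number from compound 1 to compound 4 (0.13 log units; within the scatter), no larger than the scatter. Compound 4 is estimated at 4.5 nM, with a range of 1.5 nM to 14 nM.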

Compound 4, half-maximal inhibitory concentration: 3.4 nM
Estimate against measurement, compound 4: 1.3-fold (0.12 log units) above; low and high end bracket the measured number.
By their numbers in this assay, from the lowest: compounds 3, 1, 4 and 2 (each within the scatter of the next).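

At the saturated chain carbon bound to a saturated ring carbon, acetoxymethyl in place of 1,2-dihydroxyethyl gives in this assay a 1.0-fold higher number from compound 1 to compound 4 (0.01 log units; within the scatter) and so leaves the number within the scatter. The entering group has 0 hydrogen-bond donors against 2 in the group that leaves, so in this pair the number in this assay does not depend on those donors being present. No measurement bearing on why this exchange leaves the number within the scatter is available.

Still open, as far as these compounds go, is whether an amine, a carboxylic acid ester or a longer chain at this position would also stay within the scatter of compound 1. Also open, from the compounds shown here alone, is whether acetoxymethyl behaves the same way on the 3,4-dichlorophenyl compound 2.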